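The source may report more compounds than this note shows. Statements on the series, on what has been measured and on what is new or still open speak of the compounds shown alone.

Compound 1 `O=c1c(-c2ccc(O)cc2)coc2cc(OCCCCCCCCCO)ccc12` is the starting point. Among the measured compounds shown here, in an assay (Cricetulus griseus) for inhibition of aldehyde dehydrogenase, mitochondrial (Homo sapiens) (on this read-out lower numbers stand for stronger inhibition and higher numbers for weaker inhibition), compound 1 gives 700 nM, the lowest of the two numbers known here. For the measured compounds named here, the only other measured compound, compound 2 `CCCCCCC(Oc1ccc2c(=O)c(-c3ccc(O)cc3)coc2c1)C(=O)OCC`, gives 7200 nM in this assay, a number beyond the usual scatter above that of compound 1; the two structures differ in more than one place, so their gap is not read as a single step. Compound 3 `O=c1c(-c2ccc(O)cc2)coc2cc(OCCCCCCCCCCCCO)ccc12` has not been measured. It differs from compound 1 in one place: 3-hydroxypropyl in place of hydroxy on a saturated chain carbon, nine bonds along the chain from an oxygen on an aromatic ring. Going by the values given here, no measured pair shows what this change does here, so the expectation rests on the change alone, and the step is expected to be small, with no clear direction and likely within the scatter. Compound 3 is expected to show 600 nM in this assay, within 250 nM to 1500 nM. The expected step is a 1.2-fold lower number from compound 1 to compound 3 (0.07 log units; within the scatter).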

Compound 3, half-maximal inhibitory concentration: 1700 nM
Beside the measured number, compound 3's estimate is 2.8-fold (0.45 log units) below it; the whole stated range lies below it.
By their numbers in this assay, from the lowest: compound 1; then compound 3; then compound 2.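

In this assay, the end of this chain is not a neutral place to make a change: 3-hydroxypropyl in place of hydroxy on a saturated chain carbon, nine bonds along the chain from an oxygen on an aromatic ring, gives a 2.4-fold higher number from compound 1 to compound 3 (0.39 log units; beyond the scatter). The longer chain therefore goes with weaker inhibition, although the step is modest. With the hydroxy kept at the chain end in both compounds, this pair ties the change to chain length alone, something the gap between compound 1 and compound 2 could not do. Nothing available here explains why the number rises.

Still open, going by these compounds, is whether a shorter chain would lower the number or a still longer chain would raise it further. On these data alone, it is also open how an amine or a carboxylic acid would behave in place of the hydroxy at the chain end.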